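This account rests on a few compounds, and the source may have more. Where it says the series, first, only, none or still open, it means among the compounds named here.

Measured so far:
Compound 1 `O=C1/C(=C\c2ccccc2)c2c(ncn2COCc2ccccc2)CCN1Cc1ccc(F)cc1`: 39400 nM
Compound 2 `O=C1/C(=C\c2ccccc2)c2c(ncn2COCc2ccccc2)CCN1Cc1ccc(Cl)cc1`: 47900 nM

Among the measured compounds shown here, in a functional assay on HepG2 cells (Homo sapiens) for inhibition, read by MTT assay, with a stated time of 72 h (a higher number here means a weaker inhibitor, a lower number a stronger inhibitor), compound 2 stands at 47900 nM and cannot be told apart from compound 1, the only other compound measured. Compound 3 `COc1ccc(CN2CCc3ncn(COCc4ccccc4)c3/C(=C/c3ccccc3)C2=O)cc1` keeps the rest of compound 2 and alters one group on the benzyl ring, turning 4-chlorobenzyl into 4-methoxybenzyl: methoxy in place of chloro on an aromatic carbon. In words, this is methoxy in place of chloro on an aromatic carbon, para to a large group.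

For the measured compounds named here, only one measured step bears on this change. At the same place, chloro in place of fluoro gave a 1.2-fold higher number from compound 1 to compound 2 (0.08 log units; within the scatter) and so stayed within the scatter. Going by the values given here, that step involves no methoxy group, and no measured compound carries one, so the evidence is thin. Even so, the small size of that step gives no reason to expect a real shift in this assay, and no direction can be named. The estimated change is a 1.1-fold lower number from compound 2 to compound 3 (0.05 log units; within the scatter) and is expected to stay within the scatter. For compound 3 the expected value is 43000 nM with an expected range from 20000 nM to 90000 nM in this test.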

Compound 3, half-maximal inhibitory concentration: 44400 nM
Beside the measured number, compound 3's estimate is 1.0-fold (0.01 log units) below it; measured number inside the range.
By their numbers in this assay, from the lowest: compounds 1, 3 and 2 (each within the scatter of the next).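

In this assay, putting 4-methoxybenzyl in place of 4-chlorobenzyl gives a 1.1-fold lower number from compound 2 to compound 3 (0.03 log units; within the scatter) and, measured against the fluoro compound, the methoxy group gives a 1.1-fold higher number from compound 1 to compound 3 (0.05 log units; within the scatter) at the same place. The earlier pair compared only two halogens, whereas methoxy brings in oxygen, two heavy atoms where chloro has one, and a hydrogen-bond acceptor where chloro has none. Even so, all three compounds remain within the scatter of one another in this test, so across these three groups the change on the benzyl ring has no readable effect, and no measurement available here offers an explanation for that.

An amine, a carboxylic acid or a longer chain such as butoxy at this place could still behave differently, so the lack of a readable effect cannot be extended beyond fluoro, chloro and methoxy. The remainder of the shared core is also identical in all three compounds, which leaves open how changes elsewhere in the molecule would affect the number.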